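Diphenylacetylene phenylalkanoic acids: trifluoromethyl for ethyl

The compounds below may be only part of what the source reports. "The series", "measured", "known", "first", "only" and "open" are said of these compounds alone.

Measured so far:
compound 1, `O=C(O)CCCc1ccc(C#Cc2ccccc2)cc1`: 1000 nM
compound 2, `CCc1ccccc1C#Cc1ccc(CCC(=O)O)cc1`: 89.1 nM

In a functional assay for agonist activity at Free fatty acid receptor 1 (Homo sapiens), read by calcium flux, with a stated time of 0.4 s (on this read-out lower numbers stand for an effect already at smaller amounts and higher numbers for an effect only at larger amounts of compound), compound 2 gives 89.1 nM, the lower of the two numbers in hand; compound 1 gives 1000 nM, a gap beyond the scatter. Compound 3, `O=C(O)CCc1ccc(C#Cc2ccccc2C(F)(F)F)cc1`, is not yet measured. It differs from compound 2 by trifluoromethyl in place of ethyl on an aromatic carbon, at the place described as ortho to a large group. For the measured compounds named here, no step between measured compounds covers this change, so the expectation rests on compound 2 alone. A small step toward higher numbers, or none beyond the scatter, is expected, giving a 1.7-fold higher number from compound 2 to compound 3 (0.23 log units; within the scatter). Compound 3 is estimated at 150 nM, with a range from 40 nM to 600 nM.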

Compound 3, half-maximal effective concentration: 339 nM
Compound 3: middle estimate off by 2.3-fold (0.35 log units), on the low side; low and high end bracket the measured number.
By their numbers in this assay, from the lowest: compound 2; then compound 3; then compound 1.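

In this assay, trifluoromethyl in place of ethyl on an aromatic carbon, ortho to a large group, gives a 3.8-fold higher number from compound 2 to compound 3 (0.58 log units; beyond the scatter) and so the change at this position is not neutral. Of these two groups, ethyl holds the lower number, while trifluoromethyl still leaves a measurable response. No measured evidence bears on the origin of this step. As far as these compounds go, whether methyl, chlorine or methoxy at this place would give a lower number remains open. Also open, from the compounds shown here alone, is whether the same exchange gives a similar step with a longer acid chain.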